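This account rests on a few compounds, and the source may have more. Where it says the series, first, only, none or still open, it means among the compounds named here.

Compound 1 `CCc1nc(-c2ccc(OC)cc2)c(C(=O)N2CCN(c3cccc(Cl)c3)CC2)o1`: in a functional assay on HL-60 cells (Homo sapiens) for inhibition, read by MTT assay, with a stated time of 72 h (a lower number here means a stronger inhibitor, a higher number a weaker inhibitor), compound 1 reaches only the limit > 1000 nM.
Compound 2 `Cc1nc(-c2cccc(O)c2)c(C(=O)N2CCN(c3cccc(Cl)c3)CC2)o1`: in this assay compound 2 gives 105 nM.
Compound 3 `Cc1nc(-c2ccccc2)c(C(=O)N2CCN(c3c(C)cccc3C)CC2)o1`: in this assay compound 3 gives 146 nM.

Of the two numbers measured, compound 3 carries the higher one, yet compound 2 sits within the scatter of it, so the two cannot be ordered. Compound 1 is known only through a limit, (the limit of > 1000 nM in this assay, at which 1 of the 3 values shown sits). Among the measured compounds shown here, no two of the measured compounds differ in a single place, so no measured step is available. Compound 4 `Cc1nc(-c2ccccc2)c(C(=O)N2CCN(c3ccc(C)c(C)c3)CC2)o1` differs from compound 3 by 3,4-dimethylphenyl in place of 2,6-dimethylphenyl on an amine nitrogen in a ring. With nothing measured to rest on, the change is expected to stay within the scatter: a 1.0-fold higher number from compound 3 to compound 4 (0.01 log units; within the scatter). Compound 4 is accordingly estimated at 150 nM, with a range from 50 nM to 500 nM.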

Compound 4, half-maximal inhibitory concentration: 43 nM
Compound 4: middle estimate off by 3.5-fold (0.54 log units), on the high side, outside the stated range (below it).
By their numbers in this assay, from the lowest: compound 4; then compounds 2 and 3 (each within the scatter of the next). At a limit, above all of these: compound 1.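

In this assay, among the compounds shown here, 3,4-dimethylphenyl in place of 2,6-dimethylphenyl gives a 3.4-fold lower number from compound 3 to compound 4 (0.53 log units; beyond the scatter), the first single change that can be read. The two groups have the same atoms, so, for this pair, the number responds to how the methyl groups are arranged on the phenyl ring and not to which atoms are present. No measurement given here accounts for the step.

On these data alone, it remains open how this phenyl ring fares with a single methyl, a methoxy group or a carboxylic acid in place of the two methyl groups. As far as these compounds go, whether the step holds with other groups elsewhere on the shared core also remains open.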